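Coumarin-3-carboxamide series: isobutyl in place of isopropyl

A few compounds are considered here, and "the series" means these few. Any claim that something is new, unique, unknown or untested is made for them only; others in the source may bear on it.

Of the compounds shown here, three have been measured in an in vitro assay on BTI-TN-5B1-4 cells for inhibition of Amine oxidase [flavin-containing] A (Homo sapiens), read by fluorescence; on this read-out lower numbers stand for stronger inhibition and higher numbers for weaker inhibition. Compound 1 `CCOC(=O)c1ccc(NC(=O)c2cc3ccccc3oc2=O)cc1` gives 16000 nM, and compound 2 `COc1ccc(NC(=O)c2cc3ccccc3oc2=O)cc1OC` gives 9450 nM. Compound 3 `CC(C)NC(=O)c1cc2ccc(OCc3ccccc3)cc2oc1=O` gives 63500 nM, the highest number of the three; the gaps to compound 1 and to compound 2 both lie beyond the scatter, so on the numbers shown compound 3 is the weakest inhibitor in this assay.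

Compound 4 `CC(C)CNC(=O)c1cc2ccc(OCc3ccccc3)cc2oc1=O` is not yet measured. It differs from compound 3 in one place only: isobutyl in place of isopropyl on an amide-type nitrogen. For the measured compounds named here, no measured pair shows a step of this kind, so nothing can be read off directly. The change is small and does not touch the shared core, and the expectation is a step from compound 3 to compound 4 of a 1.2-fold lower number from compound 3 to compound 4 (0.06 log units; within the scatter), that is, none beyond the scatter in either direction. Compound 4 is therefore estimated at 55000 nM in this assay, with a range from 22000 nM to 140000 nM.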

Compound 4, half-maximal inhibitory concentration: 58600 nM
Beside the measured number, compound 4's estimate is 1.1-fold (0.03 log units) below it, within the range that was stated.
By their numbers in this assay, from the lowest: compounds 2 and 1 (each within the scatter of the next); then compounds 4 and 3 (each within the scatter of the next).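

Isobutyl in place of isopropyl on the amide-type nitrogen is the first change in this series that can be read at a single place, and in this assay it gives a 1.1-fold lower number from compound 3 to compound 4 (0.03 log units; within the scatter). At this position the two branched alkyl groups therefore cannot be told apart on this read-out, so this pair gives no sign that the number depends on the choice between them. No measurement shown bears on what lies behind this flat step.

One pair does not show whether a longer chain, a cyclohexyl ring or a chain carrying an amine or a carboxylic acid on this nitrogen would move the number beyond the scatter. On these data alone, whether the same change reads alike on the other amides of the series also remains open.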